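The compounds below may be only part of what the source reports. "The series", "measured", "known", "first", "only" and "open" are said of these compounds alone.

Measured so far:
Compound 1 `Cc1ccc(C2=CC(c3ccccc3)C3=C(CC(C)(C)CC3=O)N2)cc1` was reported as "not active" (no number reported) in an assay on isolated protein for inhibition of glucose-6-phosphatase catalytic subunit 1 (Homo sapiens), read by inositol phosphate accumulation, with a stated time of 30 min, tested at 100 uM (on this read-out lower numbers stand for less inhibition and higher numbers for more inhibition at the one concentration tested (going by the name of the read-out)), with no number given.
Compound 2 `CC1(C)CC(=O)C2=C(C1)NC(C(=O)O)=CC2c1ccccc1` gives 17.1% in this assay.

Compound 2 therefore holds the only number shown; the other entry, compound 1, offers no figure to compare with. Compound 3 `COc1ccc(C2=CC(c3ccccc3)C3=C(CC(C)(C)CC3=O)N2)cc1` differs from compound 2 in one place: 4-methoxyphenyl in place of carboxy on a double-bonded ring carbon. For the measured compounds named here, no step between two measured compounds is available, so the size of this change has to be guessed from the single value of compound 2 and the absence of a number for compound 1. Since compound 2 sits at a low level already, the expected step from compound 2 to compound 3 is a small one downward, at most around the edge of the usual scatter, giving a number 11.1 percentage points lower from compound 2 to compound 3 (beyond the scatter) as the estimate. Compound 3 is accordingly expected to come out near 6%, within a range from -8% to 20%.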

Compound 3, a percentage reported as inhibition, at one concentration (the size of the read-out at that concentration, not a potency): 8.34%
Compound 3: middle estimate off by 2.3 percentage points, on the low side, within the range that was stated.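

Exchanging carboxy for 4-methoxyphenyl on this double-bonded ring carbon, next to the ring nitrogen, gives a number 8.8 percentage points lower from compound 2 to compound 3 (within the scatter) in this assay. For the compounds shown here, this is the first sign that even a large exchange here, from a group with a hydrogen-bond donor and no ring to a larger one with an aromatic ring and no such donor, does not separate the two compounds beyond ordinary scatter at the single concentration tested. Nothing measured here offers a reason for this outcome.

Going by these compounds, it remains open whether an amine or an amide at this position would shift inhibition beyond the scatter. The comparison of compound 3 with compound 1, which differs from it in one place, cannot be read, since compound 1 has no number.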